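Methoxyphenyl in Place of Pyridinyl on a Shared Core

The source may hold more compounds than are shown below. What is called first, only, known or untested is meant among the compounds shown, and "the series" means these compounds.

Of the compounds shown here, three have so far been tested in an assay on isolated protein for inhibition of RAC-alpha serine/threonine-protein kinase (Homo sapiens), read by mobility shift assay, tested at 30 uM; on this read-out lower numbers stand for less inhibition and higher numbers for more inhibition at the one concentration tested (going by the name of the read-out). Compound 1 `CC(C)(C)c1cc2nn(-c3ccccc3)c(N)c2c(=O)[nH]1` gives 7%, compound 2 `Nc1c2c(=O)[nH]c(-c3ccccc3)cc2nn1-c1ccccc1` gives -2%, and compound 3 `Nc1c2c(=O)[nH]c(-c3ccccn3)cc2nn1-c1ccccc1` gives 4%. Compound 3 thus stands second highest of the three numbers, and every gap to the other two lies within the scatter. Compound 4 `COc1ccc(-c2cc3nn(-c4ccccc4)c(N)c3c(=O)[nH]2)cc1` differs from compound 3 in one place: 4-methoxyphenyl in place of pyridin-2-yl on an aromatic carbon. For the measured compounds named here, the steps that bear on this exchange are a number 6 percentage points higher from compound 2 to compound 3 (within the scatter), a number 3 percentage points lower from compound 1 to compound 3 (within the scatter) and a number 9 percentage points lower from compound 1 to compound 2 (within the scatter), all within the scatter. Among these three compounds, exchanging the group at this place has not shifted the read-out beyond the scatter, so the expected step is no change at the digits printed from compound 3 to compound 4 (within the scatter), none beyond the scatter. Compound 4 is therefore estimated at 4%, within -8% to 16%.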

Compound 4, a percentage reported as inhibition, at one concentration (the size of the read-out at that concentration, not a potency): 16%
Compound 4: the middle estimate sits 12 percentage points below what was measured; measured number inside the range.
By their numbers in this assay, from the lowest: compounds 2, 3, 1 and 4 (each within the scatter of the next, the first and the last beyond it).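

In this assay, for the compounds shown here, a change at this position moves the number beyond the scatter for the first time: a number 12 percentage points higher from compound 3 to compound 4 (beyond the scatter), and with methoxy in place of hydrogen on an aromatic carbon, a number 18 percentage points higher from compound 2 to compound 4 (beyond the scatter). The tert-butyl comparison stays unresolved, with a number 9 percentage points higher from compound 1 to compound 4 (within the scatter), so 4-methoxyphenyl stands apart from phenyl and pyridin-2-yl but not from tert-butyl. No supporting evidence is available to account for these steps.

On these data alone, it remains open whether a hydroxyl group, an amine or a longer alkoxy chain in place of methoxy would give a different number.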